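Benzyl amide aromatic substituent: methyl to fluoro

The source may report more compounds than this note shows. Statements on the series, on what has been measured and on what is new or still open speak of the compounds shown alone.

Working notes on the series. Compound 1 `CN(C)CCCCCN(C)C1=Nc2ccccc2C(CC(=O)NCc2ccccc2)N1c1ccc(-c2ccccn2)cc1` in a functional assay on cells (Homo sapiens) for cytotoxicity, read by MTT assay, with a stated time of 48 h (a higher number here means a weaker inhibitor, a lower number a stronger inhibitor), reports only a limit of the assay, > 5000 nM, and no number (the limit of > 5000 nM in this assay, at which 1 of the 3 values shown sits). Compound 2 `CN(C)CCN1CCN(C2=Nc3ccccc3C(CC(=O)NCc3ccccc3)N2c2ccc(-c3ccccc3)cc2)CC1` gives 2390 nM in this assay. Compound 3 `Cc1ccc(CNC(=O)CC2c3ccccc3N=C(N3CCN(CCN(C)C)CC3)N2c2ccc(-c3ccccc3)cc2)cc1` gives 3520 nM in this assay; this is the higher of the two numbers shown, compound 2 being nearest, and the step of a 1.5-fold higher number from compound 2 to compound 3 (0.17 log units; within the scatter) stays within the scatter, so no order between the two can be read.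

Compound 4 `CN(C)CCN1CCN(C2=Nc3ccccc3C(CC(=O)NCc3ccc(F)cc3)N2c2ccc(-c3ccccc3)cc2)CC1` differs from compound 3 by fluoro in place of methyl on an aromatic carbon. Going by the values given here, the only measured step at the same place is the one from compound 2 to compound 3, a methyl entering on that aromatic carbon, and it stayed within the scatter. Among the compounds with values here, no measured step shows a fluoro entering. Within the data shown here, with that as the sole guide, the expected step is a 1.2-fold lower number from compound 3 to compound 4 (0.07 log units; within the scatter), in no direction beyond the scatter. For compound 4 the estimated value in this assay is 3000 nM, with a range from 1200 nM to 7500 nM.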

Compound 4, half-maximal inhibitory concentration: 4000 nM
Compound 4: the middle estimate sits 1.3-fold (0.12 log units) below what was measured; low and high end bracket the measured number.
By their numbers in this assay, from the lowest: compounds 2, 3 and 4 (each within the scatter of the next). At a limit, above all of these: compound 1.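

Fluoro in place of methyl on this aromatic carbon gives a 1.1-fold higher number from compound 3 to compound 4 (0.06 log units; within the scatter) in this assay, and fluoro in place of hydrogen gives a 1.7-fold higher number from compound 2 to compound 4 (0.22 log units; within the scatter). Hydrogen, methyl and fluoro on the carbon para to a large group thus all lie within the scatter of one another, whereas the earlier compounds covered only hydrogen and methyl, so this first fluoro adds no separation at this position. Nothing measured here bears on a cause for this reading.

Still open, going by these compounds, is whether a group of another kind on this carbon, such as a carboxylic acid, an amine or a methoxy group, would move the number beyond the scatter. Also open, on these data alone, is whether a chlorine on another carbon of the same ring would read any differently.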